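Cyano for Methyl on a Fused Aromatic Ring

The source may hold more compounds than are shown below. What is called first, only, known or untested is meant among the compounds shown, and "the series" means these compounds.

Of the compounds shown here, three have been measured in a functional assay on cells for agonist activity at Free fatty acid receptor 1 (Mus musculus), read by FLIPR and calcium flux, with a stated time of 5 min; on this read-out lower numbers stand for smaller maximal responses and higher numbers for larger maximal responses. Compound 1 `Cc1nn(-c2ccccn2)c2cc(-c3cccc(CCC(=O)O)c3)ccc12` gives 0%, compound 2 `COc1nn(-c2ccccn2)c2cc(-c3ccc(CCC(=O)O)cc3)ccc12` gives 96%, and compound 3 `Cc1cc(-c2ccc(CCC(=O)O)cc2)cc2c1cnn2-c1ccccn1` gives 82%. Compound 3 thus stands second of the three numbers: compound 2 lies above it by a margin beyond the scatter, and compound 1 lies far below it, also beyond the scatter. Among the measured compounds shown here, no two of the measured compounds differ in only one place, so no single step between them is known.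

Compound 4 `N#Cc1cc(-c2ccc(CCC(=O)O)cc2)cc2c1cnn2-c1ccccn1` has not yet been measured in this assay. It differs from compound 3 in one place: cyano in place of methyl on an aromatic carbon. A methyl leaves and a cyano enters, on an aromatic carbon of a six-membered aromatic ring of carbon only, part of a fused system of two rings, ortho to a fused ring, meta to a fused ring and meta to a large group.

For the measured compounds named here, nothing among the measured compounds shows what this change does in this assay. The step from compound 3 to compound 4 is expected to be a number 4 percentage points lower from compound 3 to compound 4 (within the scatter), which is to say small and most likely within the scatter, with no firm direction. Compound 4 is therefore expected to give about 78%, within a range from 45% to 100%.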

Compound 4, largest response reached (reported as efficacy), in percent of the reference or control that the assay uses in the Free fatty acid receptor 1 assay: 113%
The estimate for compound 4 lay 35 percentage points below the measured number, and the stated range ends below it.
By their numbers in the Free fatty acid receptor 1 assay, from the lowest: compound 1; then compound 3; then compound 2; then compound 4.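

The step shows that this aromatic carbon, ortho to a fused ring and meta to a large group, does more than tolerate a change of substituent: in the Free fatty acid receptor 1 assay, cyano in place of methyl gives a number 31 percentage points higher from compound 3 to compound 4 (beyond the scatter). Among the compounds shown here, the earlier compounds held no pair differing in one place, so only this step ties a change at this carbon to a shift in maximal response. In a physicochemical assay for lipophilicity, using the shake flask method, measured as octanol-water partition, with a stated time of 30 min, at pH 7.4 (a higher number here means a more lipophilic compound, a lower number a more polar compound), compound 3 gives 2.6 and compound 4 gives 2.2, so in this pair the larger maximal response comes with a lower distribution coefficient, not a higher one.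

A single pair cannot tell whether the gain belongs to the cyano group itself or would also follow other groups on this carbon, such as a chlorine atom, a methoxy group or a primary amide. It also leaves open whether cyano in place of methyl would give a step of this size at other carbons of the shared core, or with the propanoic acid chain placed as in compound 1.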